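Series notes: aryl group change on the shared core

The source may report more compounds than this note shows. Statements on the series, on what has been measured and on what is new or still open speak of the compounds shown alone.

Of the compounds shown here, two have numbers so far. Compound 1 `Cc1ccc(-c2c(C)nn(-c3nc(-c4ccc(Cl)c(Cl)c4)c(SC(C)C)s3)c2C(=O)O)cc1` gives 3800 nM in a functional assay on BJAB cells (Homo sapiens) for antiproliferative activity, with a stated time of 4 days; on this read-out higher numbers stand for an effect only at larger amounts of compound and lower numbers for an effect already at smaller amounts. Compound 2 `COc1ccc(-c2c(C)nn(-c3nc(-c4ccc(Cl)c(Cl)c4)c(SC(C)C)s3)c2C(=O)O)cc1` gives 2100 nM in this assay, and stands lowest of the two numbers, with compound 1 nearest; the step of a 1.8-fold lower number from compound 1 to compound 2 (0.26 log units; within the scatter) lies within the scatter, so no order between the two can be read.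

Compound 3 `COc1cc(Cl)cc(-c2c(C)nn(-c3nc(-c4ccc(Cl)c(Cl)c4)c(SC(C)C)s3)c2C(=O)O)c1` is not yet measured. It differs from compound 2 as follows: 3-chloro-5-methoxyphenyl in place of 4-methoxyphenyl on an aromatic carbon.

Going by the values given here, the only measured step swaps methoxy for methyl on the same aromatic carbon and stays within the scatter. Among the compounds with values here, no measured step covers a chlorine entering that ring or the methoxy moving. On the numbers shown, no step beyond the scatter is expected, so the number for compound 3 is estimated near that of compound 2, as a step of a 1.0-fold higher number from compound 2 to compound 3 (0.02 log units; within the scatter). Compound 3 is estimated at 2200 nM in this assay, with a range from 700 nM to 7000 nM.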

Compound 3, half-maximal effective concentration: 760 nM
Beside the measured number, compound 3's estimate is 2.9-fold (0.46 log units) above it, and the stated range covers the measured number.
By their numbers in this assay, from the lowest: compound 3; then compounds 2 and 1 (each within the scatter of the next).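

In this assay this aromatic carbon proves sensitive to the aryl group it carries: 3-chloro-5-methoxyphenyl in place of 4-methoxyphenyl gives a 2.8-fold lower number from compound 2 to compound 3 (0.44 log units; beyond the scatter) and in place of 4-methylphenyl gives a 5.0-fold lower number from compound 1 to compound 3 (0.70 log units; beyond the scatter) while the earlier swap of methoxy for methyl stayed within the scatter. This change adds a chlorine and also alters where the methoxy sits on the ring, so the step belongs to the 3-chloro-5-methoxyphenyl group as a whole and not to either alteration alone. No evidence on hand accounts for the step.

The compounds shown do not separate the two alterations, which would take a phenyl ring carrying only the chlorine or only the methoxy. As far as these compounds go, how a nitrile or an amine in place of the chlorine would read also remains open.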